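The compounds below may be only part of what the source reports. "The series", "measured", "known", "first", "only" and "open" are said of these compounds alone.

Measured so far in a functional assay on PC-3 cells (Homo sapiens) for inhibition; on this read-out lower numbers stand for stronger inhibition and higher numbers for weaker inhibition: compound 1 `COc1cc2nc(N3CCN(C(=O)OCc4ccccc4)CC3)nc(N)c2cc1OC` gives 63000 nM; compound 2 `COc1cc2nc(N3CCN(C(=O)c4ccc(C(C)(C)C)cc4)CC3)nc(N)c2cc1OC` gives 47000 nM; compound 3 `COc1cc2nc(N3CCN(S(=O)(=O)c4ccc(C)cc4)CC3)nc(N)c2cc1OC` gives 30000 nM.

Among the measured compounds shown here, compound 3 carries the lowest of these three numbers, but its gap to compound 2 lies within the scatter; only the step of a 2.1-fold lower number from compound 1 to compound 3 (0.32 log units; beyond the scatter) is beyond it. Compound 4 `COc1cc2nc(N3CCN(S(=O)(=O)c4ccc(-c5ccccc5)cc4)CC3)nc(N)c2cc1OC` differs from compound 3 in one place: phenyl in place of methyl on an aromatic carbon. For the measured compounds named here, no measured step enlarges this group, so the only guidance is indirect: a 1.3-fold lower number from compound 1 to compound 2 (0.13 log units; within the scatter) and a 2.1-fold lower number from compound 1 to compound 3 (0.32 log units; beyond the scatter), both small changes at the same position of the shared core. A step of similar, small size is therefore expected in this assay, in either direction or none beyond the scatter. Compound 4 is estimated at 22000 nM, with a range from 7000 nM to 65000 nM. This estimate means an expected step of a 1.4-fold lower number from compound 3 to compound 4 (0.13 log units; within the scatter).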

Compound 4, half-maximal inhibitory concentration: 4200 nM
Estimate against measurement, compound 4: 5.2-fold (0.72 log units) above; the whole stated range lies above it.
By their numbers in this assay, from the lowest: compound 4; then compounds 3, 2 and 1 (each within the scatter of the next, the first and the last beyond it).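

In this assay, phenyl in place of methyl on this aromatic carbon gives a 7.1-fold lower number from compound 3 to compound 4 (0.85 log units; beyond the scatter), the largest step among the compounds shown. The earlier steps shown here swapped the whole group on the ring nitrogen and moved the number far less, so this outer carbon, para to a large group, matters more than those swaps suggested. Nothing shown gives a reason for this step. As far as these compounds go, it remains open whether a saturated cyclohexyl ring or a small ethyl group here would do the same, and whether an amine or carboxylic acid on the added phenyl would shift the number further.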